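Swapping Acetyl for Cyano on a Sulfonyl-Bearing Chain

A few compounds are considered here, and "the series" means these few. Any claim that something is new, unique, unknown or untested is made for them only; others in the source may bear on it.

Of the compounds shown here, three built on a shared core have been tested in a functional assay on PC-3 cells (Homo sapiens) for inhibition, read by sulforhodamine B assay, with a stated time of 48 h; on this read-out higher numbers stand for weaker inhibition of growth and lower numbers for stronger inhibition of growth. Compound 1 `CCOC(=O)C(=Cc1c(-c2ccccc2)[nH]c2ccccc12)C(=O)OCC` gives 3300 nM. Compound 2 `CC(=O)/C(=C\c1c(-c2ccccc2)[nH]c2ccccc12)S(=O)(=O)c1ccccc1` gives 2500 nM. Compound 3 `COc1ccc(-c2[nH]c3ccc(OC)cc3c2C=C(C#N)C#N)cc1` gives 342 nM. Among these three numbers compound 2 stands second highest; its nearest neighbour is compound 1, whose number sits within the scatter of repeated measurements, while compound 3 lies furthest away, with a lower number that is beyond the scatter.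

The next compound, compound 4 `N#C/C(=C\c1c(-c2ccccc2)[nH]c2ccccc12)S(=O)(=O)c1ccccc1`, has not yet been measured in this assay. It differs from compound 2 in one place: cyano in place of acetyl on a double-bonded chain carbon bound to a double-bonded chain carbon and a sulfonyl sulfur. Among the measured compounds shown here, no step between two measured compounds isolates this exact change, so any expectation rests on the whole set. Compound 3, which carries cyano groups on its chain but also differs elsewhere, gives 342 nM, and that is the only hint that a cyano-bearing chain may go with stronger inhibition of growth.

The step of a 2.1-fold lower number from compound 2 to compound 4 (0.32 log units; beyond the scatter) is expected to be modest, toward stronger inhibition of growth, and it may well fall within the scatter. Compound 4 is estimated at 1200 nM, with a likely range from 350 nM to 4000 nM.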

Compound 4, concentration for 50% growth inhibition: 3400 nM
Compound 4: the middle estimate sits 2.8-fold (0.45 log units) below what was measured; the range from low to high includes it.
By their numbers in this assay, from the lowest: compound 3; then compounds 2, 1 and 4 (each within the scatter of the next).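

In this assay, putting cyano in place of acetyl on this sulfonyl-bearing chain gives a 1.4-fold higher number from compound 2 to compound 4 (0.13 log units; within the scatter) and so leaves the two compounds indistinguishable. At this position, then, a cyano does not by itself bring stronger inhibition of growth, and the acetyl carbonyl is not needed to keep the activity seen with compound 2. No measurement shown here explains why the two groups read alike.

On these data alone, whether a carboxylic acid, an amide or a longer chain such as propionyl at this same place would also read alike remains open. So does whether cyano and acetyl would still match if the sulfonyl group on the chain were replaced by another group, or if the shared core carried methoxy groups.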